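Replacing 1,3-benzothiazol-5-yl with 1H-indazol-4-yl in compound 3

The source may report more compounds than this note shows. Statements on the series, on what has been measured and on what is new or still open speak of the compounds shown alone.

Values in an ADME assay (liver) for metabolic stability, with Liver microsome (Homo sapiens) as the target, using microsomes and NADPH, with a stated time of 30 min, tested at 1 uM (a lower number here means slower removal, a higher number faster removal of the compound), follow
compound 1 `CC(C)(C)n1cc(-c2cc(C(O)(C(F)(F)F)C(F)(F)F)cnc2N2CCN(S(=O)(=O)c3ccc(N)nc3)CC2)cn1` gives 86 mL.min-1.g-1
compound 2 `Cc1csc(-c2cc(C(O)(C(F)(F)F)C(F)(F)F)cnc2N2CCN(S(=O)(=O)c3ccc(N)nc3)CC2)c1` gives 29 mL.min-1.g-1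
compound 3 `Nc1ccc(S(=O)(=O)N2CCN(c3ncc(C(O)(C(F)(F)F)C(F)(F)F)cc3-c3ccc4scnc4c3)CC2)cn1` gives 39 mL.min-1.g-1

Compound 3 stands close to compound 2 and clearly apart from compound 1. This shows in a 1.3-fold higher number from compound 2 to compound 3 (0.13 log units; within the scatter) and in a 2.2-fold lower number from compound 1 to compound 3 (0.34 log units; beyond the scatter) on the same scale. Compound 4 `Nc1ccc(S(=O)(=O)N2CCN(c3ncc(C(O)(C(F)(F)F)C(F)(F)F)cc3-c3cccc4[nH]ncc34)CC2)cn1` keeps the shared core and changes one group, with 1H-indazol-4-yl in place of 1,3-benzothiazol-5-yl on an aromatic carbon in the structure. Within the data shown here, no measured step tests this exact swap, so the nearest guides are other swaps at the same place. Replacing 1-(tert-butyl)-1H-pyrazol-4-yl gave modest steps, seen in a 3.0-fold lower number from compound 1 to compound 2 (0.47 log units; beyond the scatter) and again in the step to compound 3 above. The group leaving compound 3 is not that one, and the swap between the two other groups gave only a 1.3-fold higher number from compound 2 to compound 3 (0.13 log units; within the scatter) in this assay as its size. The expected change is therefore small, namely a 1.1-fold lower number from compound 3 to compound 4 (0.05 log units; within the scatter) and so no shift beyond the scatter. Compound 4 is estimated at 35 mL.min-1.g-1 with an expected range from 16 mL.min-1.g-1 to 75 mL.min-1.g-1 in this assay as the read-out.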

Compound 4, intrinsic clearance in microsomes: 42 mL.min-1.g-1
Beside the measured number, compound 4's estimate is 1.2-fold (0.08 log units) below it, within the range that was stated.
By their numbers in this assay, from the lowest: compounds 2, 3 and 4 (each within the scatter of the next); then compound 1.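

In this assay, exchanging 1,3-benzothiazol-5-yl for 1H-indazol-4-yl adds a hydrogen-bond donor and removes a hydrogen-bond acceptor, yet it gives a 1.1-fold higher number from compound 3 to compound 4 (0.03 log units; within the scatter), so this read-out does not separate these two groups at this aromatic carbon. Among these compounds, the new compound is also not separated from the 4-methylthiophen-2-yl analogue, with a 1.4-fold higher number from compound 2 to compound 4 (0.16 log units; within the scatter), whereas a 2.0-fold lower number from compound 1 to compound 4 (0.31 log units; beyond the scatter) shows that among the four compounds only the one carrying 1-(tert-butyl)-1H-pyrazol-4-yl stands apart from the other three. Nothing available here explains why these three groups give such similar numbers.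

As far as these compounds go, what remains open is how the clearance would respond to a simple amine or a carboxylic acid on this same carbon. Whether the hydrogen-bond donor count matters at all also stays unsettled, since one exchange at one position cannot decide that.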